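A few compounds are considered here, and "the series" means these few. Any claim that something is new, unique, unknown or untested is made for them only; others in the source may bear on it.

Measured so far:
compound 1 `COC(=O)c1cc(-c2csc(N/N=C/c3cccs3)n2)ccc1OCc1ccccc1` — 96%
compound 2 `Clc1ccc(-c2csc(N/N=C/c3cccs3)n2)cc1` — 96.6%

In a functional assay, read by spectrophotometry, with a stated time of 15 min, tested at 80 ug/mL (a lower number here means a weaker effect, a higher number a stronger effect of the compound at the concentration tested), compound 1 gives 96%, the lower of the two numbers, with compound 2 at 96.6%; the two lie within the scatter of each other. Compound 3 `COC(=O)c1cc(-c2csc(N/N=C/c3ccc(Cl)cc3Cl)n2)ccc1OCc1ccccc1` is not yet measured. It differs from compound 1 in one place: 2,4-dichlorophenyl in place of thiophen-2-yl on a carbon with a double bond to nitrogen. For the measured compounds named here, no step between measured compounds is known here, and both values sit near the top of the read-out. The change from compound 1 to compound 3 is expected to give no step beyond the scatter in this assay, a number 3 percentage points lower from compound 1 to compound 3 (within the scatter). Compound 3 is thus estimated at 93%, within 80% to 99%.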

Compound 3, a percentage reported as inhibition, at one concentration (the size of the read-out at that concentration, not a potency): 45.5%
The estimate for compound 3 lay 47.5 percentage points above the measured number; the measured number lies below the stated range.
By their numbers in this assay, from the lowest: compound 3; then compounds 1 and 2 (each within the scatter of the next).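

In this assay, the place on the carbon with a double bond to nitrogen proves sensitive to the group it carries: 2,4-dichlorophenyl in place of thiophen-2-yl gives a number 50.5 percentage points lower from compound 1 to compound 3 (beyond the scatter). Compound 1 and compound 2 both carry thiophen-2-yl there, so they could not show this. No data here bear on what lies behind the step.

As far as these compounds go, whether the drop follows from the chlorines or from the change of ring stays open; an unsubstituted phenyl or a furan-2-yl at this place would separate the two. From the compounds shown here alone, whether the same change has a similar effect on the core of compound 2 is also open.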